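A few compounds are considered here, and "the series" means these few. Any claim that something is new, unique, unknown or untested is made for them only; others in the source may bear on it.

Working notes on the series.

Three compounds share one core and differ only in the aryl group on the sulfonyl sulfur. Compound 1 `Cc1ccc(S(=O)(=O)N(C)c2ccc3[nH]c(-c4n[nH]c5ccccc45)cc3n2)cc1` gives 27100 nM in a functional assay on A549 cells (Homo sapiens) for antiproliferative activity, read by MTT assay, with a stated time of 72 h; a higher number here means a weaker inhibitor, a lower number a stronger inhibitor. Compound 2 `CN(c1ccc2[nH]c(-c3n[nH]c4ccccc34)cc2n1)S(=O)(=O)c1ccc(Br)cc1` gives 19700 nM in this assay. Compound 3 `COc1ccc(OC)c(S(=O)(=O)N(C)c2ccc3[nH]c(-c4n[nH]c5ccccc45)cc3n2)c1` gives 19400 nM in this assay. Compound 3 holds the lowest of the three numbers, but its gaps to compound 2 and to compound 1 are both within the scatter, so no order among the three can be read from these values.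

The next member, compound 4 `CN(c1ccc2[nH]c(-c3n[nH]c4ccccc34)cc2n1)S(=O)(=O)c1ccc(OC(F)(F)F)cc1`, is still to be measured. The change from compound 3 is 4-(trifluoromethoxy)phenyl in place of 2,5-dimethoxyphenyl on a sulfonyl sulfur.

For the measured compounds named here, the steps that bear on this change are those already made at the sulfonyl sulfur: a 1.4-fold lower number from compound 1 to compound 3 (0.15 log units; within the scatter) and a 1.0-fold lower number from compound 2 to compound 3 (0.01 log units; within the scatter), alongside a 1.4-fold lower number from compound 1 to compound 2 (0.14 log units; within the scatter) at the aromatic carbon of the same aryl group. None of these exchanges of the aryl group on the sulfonyl sulfur moved the number beyond the scatter, so the expectation for compound 4 in this assay is a step of no real size, a 1.0-fold higher number from compound 3 to compound 4 (0.01 log units; within the scatter), in no preferred direction.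

The estimated value for compound 4 in this assay is therefore 20000 nM, with a range from 10000 nM to 40000 nM.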

Compound 4, half-maximal inhibitory concentration: 8000 nM
Compound 4: the middle estimate sits 2.5-fold (0.40 log units) above what was measured; the whole stated range lies above it.
By their numbers in this assay, from the lowest: compound 4; then compounds 3, 2 and 1 (each within the scatter of the next).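

At the aryl group on the sulfonyl sulfur, 4-(trifluoromethoxy)phenyl is the only group shown that moves the number beyond the scatter in this assay, with a 2.4-fold lower number from compound 3 to compound 4 (0.38 log units; beyond the scatter) in place of 2,5-dimethoxyphenyl. The same separation appears at the aromatic carbon of that aryl group, with a 2.5-fold lower number from compound 2 to compound 4 (0.39 log units; beyond the scatter) for trifluoromethoxy in place of bromo and a 3.4-fold lower number from compound 1 to compound 4 (0.53 log units; beyond the scatter) for trifluoromethoxy in place of methyl, so this position is not flat as compound 1, compound 2 and compound 3 alone suggested, although all three steps remain modest. No supporting measurement accompanies these compounds, so the result carries no assigned cause.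

With only one group breaking from the others, the compounds shown cannot tell whether the step is particular to trifluoromethoxy or would extend to an ethoxy group, a trifluoromethyl group, an amine or a carboxylic acid on the same aryl ring. The shared core is constant throughout and only one cell assay is shown, so it also stays open whether the step would persist on a changed core or in other cells.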